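A few compounds are considered here, and "the series" means these few. Any claim that something is new, unique, unknown or untested is made for them only; others in the source may bear on it.

Of the compounds shown here, two have so far been tested in a functional assay on the whole organism for inhibition, with Rattus norvegicus as the target, at a dose of 30 mg/kg; on this read-out higher numbers stand for more inhibition at the one dose given (going by the name of the read-out) and lower numbers for less inhibition. Compound 1 `Nc1ncnn1/C(S)=N/CCCCCO` gives -17% in this assay. Compound 2 `CN(C)C(=S)n1ncnc1N` gives 34% in this assay, the higher of the two numbers; its nearest neighbour is compound 1, whose number lies lower by a margin beyond the usual scatter. Compound 3 `CSC(=S)n1ncnc1N` has not yet been measured. Compared with compound 2 it differs in one place: methylsulfanyl in place of dimethylamino on a thiocarbonyl carbon. Among the compounds with values here, no pair of measured compounds differs in a single place, and the two numbers in hand say nothing about what such a swap on the thiocarbonyl carbon does. The expectation is a modest fall from compound 2 to compound 3, a number 14 percentage points lower from compound 2 to compound 3 (beyond the scatter), though a step of no size beyond the scatter would not be surprising. Compound 3 is accordingly expected to give about 20% in this assay, within a range from -15% to 50%.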

Compound 3, a percentage reported as inhibition, in the whole organism at one dose (the size of the read-out at that dose, not a potency): 36%
For compound 3 the middle estimate is 16 percentage points below the measured one, and the stated range covers the measured number.
By their numbers in this assay, from the lowest: compound 1; then compounds 2 and 3 (each within the scatter of the next).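

In this assay, within the data shown here, methylsulfanyl in place of dimethylamino on a thiocarbonyl carbon gives a number 2 percentage points higher from compound 2 to compound 3 (within the scatter) and so provides the first comparison here between compounds that differ in one place. At this position, the swap leaves the read-out unchanged within the scatter, although the entering group carries sulfur and the leaving group carries nitrogen. No measurement shown here offers a reason for this match.

As far as these compounds go, whether the same holds for other groups on the thiocarbonyl carbon remains open: ethylsulfanyl, with its longer chain, or an unsubstituted amino group might give a different number. From the compounds shown here alone, each compound also has a reading at only one dose, so how compound 2 and compound 3 compare at other doses is unknown.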